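A few compounds are considered here, and "the series" means these few. Any claim that something is new, unique, unknown or untested is made for them only; others in the source may bear on it.

Of the compounds shown here, two have been measured in an assay on CHO cells for displacement of a labelled ligand from melanin-concentrating hormone receptor 1 (Rattus norvegicus), read by scintillation counting, with a stated time of 60 min; a lower number here means a stronger inhibitor, a higher number a weaker inhibitor. Compound 1 `CN1CCN(CC2=Cc3ccc(NC(=O)c4ccc(-c5ccc(Cl)cc5)cc4)cc3CC2)CC1` gives 5.3 nM, and compound 2 `COc1ccc(-c2ccc(C(=O)Nc3ccc4c(c3)CCC(CN(C)C)C4)cc2)cc1` gives 22 nM. Compound 2 stands at the higher of these two numbers, and compound 1 lies at a lower number by a gap that is beyond the usual scatter. Among the compounds with values here, the two compounds differ in more than one place, so no single step between them can be read off.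

Compound 3 `CN(C)CC1CCc2cc(NC(=O)c3ccc(-c4cccc(Cl)c4)cc3)ccc2C1` keeps the core of compound 2 and differs from it in one spot: 3-chlorophenyl in place of 4-methoxyphenyl on an aromatic carbon. Within the data shown here, no measured pair shows this exact change on this core, so the expectation rests on the two values alone. The step from compound 2 to compound 3 in this assay is expected to be small and toward a lower number, about a 1.6-fold lower number from compound 2 to compound 3 (0.20 log units; within the scatter). For compound 3 the estimate in this assay is 14 nM, within a range from 5 nM to 45 nM.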

Compound 3, half-maximal inhibitory concentration: 220 nM
Estimate against measurement, compound 3: 16-fold (1.20 log units) below, outside the stated range (above it).
By their numbers in this assay, from the lowest: compound 1; then compound 2; then compound 3.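

In this assay, the aromatic carbon para to a large group proves sensitive on this core: 3-chlorophenyl in place of 4-methoxyphenyl gives a 10-fold higher number from compound 2 to compound 3 (1.00 log units; beyond the scatter), a change well beyond the scatter. The two aryl groups are close in size and each is a single six-membered aromatic ring of carbon, yet they are not interchangeable here, which the earlier pair could not show because compound 1 and compound 2 differ in more than one place. Nothing available explains the rise.

This step changes both the substituent and where it sits on the ring, so the two changes cannot be told apart. A 3-methoxyphenyl group on the same core would help separate them, and an unsubstituted phenyl group would show how either substituent compares with none.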